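Cytotoxicity Outlook for a Trifluoromethylbenzyl Analogue

The source may hold more compounds than are shown below. What is called first, only, known or untested is meant among the compounds shown, and "the series" means these compounds.

Measured compounds:
compound 1 `CCOC(=O)c1sc(-c2ccccc2)nc1N1CCC(NCc2ccc(F)cc2)CC1`: 6.23%
compound 2 `CCOC(=O)c1sc(-c2ccccn2)nc1N1CCC(NCc2ccc(F)cc2)CC1`: 12.6%
compound 3 `CCOC(=O)c1sc(-c2ccccn2)nc1N1CCC(NCc2ccc(OCc3ccccc3)cc2)CC1`: 12.8%

In an ADME assay on RAW264.7 cells (Mus musculus) for cytotoxicity, read by MTT assay, with a stated time of 72 h, tested at 50 uM (a lower number here means less inhibition, a higher number more inhibition at the concentration tested (going by the name of the read-out)), compound 2 gives 12.6% and sits in the middle of the three numbers, though its gaps to compound 3 and to compound 1 are both within the scatter. Compound 4 `CCOC(=O)c1sc(-c2ccccn2)nc1N1CCC(NCc2cccc(C(F)(F)F)c2)CC1` differs from compound 2 in one place: 3-(trifluoromethyl)phenyl in place of 4-fluorophenyl on a saturated chain carbon bound to an amine nitrogen. For the measured compounds named here, two measured steps bear on this. The change at the same place, a number 0.2 percentage points higher from compound 2 to compound 3 (within the scatter), and the change elsewhere, a number 6.4 percentage points higher from compound 1 to compound 2 (within the scatter), were both within the scatter. Because a number 0.2 percentage points higher from compound 2 to compound 3 (within the scatter) was so small, no step beyond the scatter is expected here; the expected step is a number 0.4 percentage points higher from compound 2 to compound 4 (within the scatter). Compound 4 is therefore estimated at 13%, with a range from 3% to 25%.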

Compound 4, a percentage reported as inhibition, at one concentration (the size of the read-out at that concentration, not a potency): 19.2%
Compound 4: the middle estimate sits 6.2 percentage points below what was measured; low and high end bracket the measured number.
By their numbers in this assay, from the lowest: compounds 1, 2, 3 and 4 (each within the scatter of the next, the first and the last beyond it).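

At this place, on a saturated chain carbon bound to an amine nitrogen, 3-(trifluoromethyl)phenyl in place of 4-fluorophenyl gives a number 6.6 percentage points higher from compound 2 to compound 4 (within the scatter) in this assay. Together with a number 0.2 percentage points higher from compound 2 to compound 3 (within the scatter), this makes two different changes to this benzyl group that both stay inside the scatter. Nothing measured here explains the size of either step. Still open, going by these compounds, is whether an amine or a carboxylic acid on that phenyl ring, or a longer chain in place of the benzyl link, would give a step beyond the scatter.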